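A few compounds are considered here, and "the series" means these few. Any claim that something is new, unique, unknown or untested is made for them only; others in the source may bear on it.

Compound 1 `COc1ccc2[nH]c(C(=O)N3CC(=O)N(Cc4ccccc4)[C@@H](CN4CCCCC4)C3)cc2c1`: 76900 nM
Compound 2 `COc1cccc(CN2C(=O)CN(C(=O)c3cc4cc(OC)ccc4[nH]3)C[C@@H]2CC2CCCCC2)c1`: > 10000 nM

In an ADME assay on Vero cells (Chlorocebus sabaeus) for cytotoxicity, with a stated time of 7 days (a higher number here means that more compound is tolerated, a lower number that less compound is tolerated), compound 1 stands as the only number shown. Compound 2 reaches only (the limit of > 10000 nM in this assay, at which 1 of the 2 values shown sits), which is a limit and not a number. No step between measured compounds is shown. Compound 3 `COc1ccc2[nH]c(C(=O)N3CC(=O)N(Cc4ccccc4)[C@@H](CN4CC5CC5C4)C3)cc2c1` differs from compound 1 in a group of 6 heavy atoms (5 carbon, 1 nitrogen; one three-membered non-aromatic ring of carbon only, one five-membered non-aromatic ring with 1 hetero atom) in place of a group of 6 heavy atoms (5 carbon, 1 nitrogen; one six-membered non-aromatic ring with 1 hetero atom), on a saturated chain carbon bound to a saturated ring carbon. The step from compound 1 to compound 3 is expected to be small, a 1.1-fold lower number from compound 1 to compound 3 (0.04 log units; within the scatter), a change of no clear direction and within the scatter. Compound 3 is therefore estimated at 70000 nM in this assay, with a range from 30000 nM to 160000 nM.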

Compound 3, half-maximal cytotoxic concentration: 13800 nM
Beside the measured number, compound 3's estimate is 5.1-fold (0.71 log units) above it, outside the stated range (below it).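

In this assay, this position on a saturated chain carbon bound to a saturated ring carbon responds to the shape of the ring group alone: replacing piperidin-1-yl with the group holding a three-membered and a five-membered ring, equal in heavy atoms and hydrogen-bond acceptors, gives a 5.6-fold lower number from compound 1 to compound 3 (0.75 log units; beyond the scatter). Nothing shown accounts for this step. The compounds shown leave open whether morpholine or an open-chain diethylamino group at this place would fall nearer compound 1 or compound 3.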